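From Trifluoromethyl to a Piperidine Amide

The source may hold more compounds than are shown below. What is called first, only, known or untested is meant among the compounds shown, and "the series" means these compounds.

Compound 2 `O/N=C(/Nc1cccc(C(F)(F)F)c1)c1ccc2occc2c1` gives 1200 nM in an assay on isolated protein for inhibition of Indoleamine 2,3-dioxygenase 1 (Homo sapiens), read by spectrophotometry (a lower number here means a stronger inhibitor, a higher number a weaker inhibitor), and compound 1 `O/N=C(/Nc1cccc(Cl)c1)c1ccc2occc2c1` gives 690 nM there. Going by the values given here, the only measured step, a 1.7-fold higher number from compound 1 to compound 2 (0.24 log units; within the scatter) lies within the scatter, so the two compounds stand level. Compound 3 `CC1CCN(C(=O)c2cccc(N/C(=N/O)c3ccc4occc4c3)c2)CC1` differs from compound 2 by (4-methylpiperidin-1-yl)carbonyl in place of trifluoromethyl on an aromatic carbon in the words of the comparison. Among the compounds with values here, no measured step involves such a group, and the single step within the scatter gives no direction. The step expected for compound 3 is no change at the digits printed from compound 2 to compound 3 (within the scatter) in either direction. The estimate for compound 3 is 1200 nM with a range from 250 nM up to 6000 nM in this assay.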

Compound 3, half-maximal inhibitory concentration: > 30000 nM
Compound 3: a limit, no number; the forecaster's own chance of this, stated with the estimate: 10%; middle value at least 25-fold (1.39 log units) away from the limit.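

In this assay the value of compound 3 is a limit of the assay and not a number: the limit of > 30000 nM in this assay, at which 1 of the 3 values shown sits. Even so, the position that held chloro and trifluoromethyl level proves not to tolerate every group: (4-methylpiperidin-1-yl)carbonyl in place of trifluoromethyl gives an at least 25-fold higher number from compound 2 to compound 3 (1.39 log units; beyond the scatter), and in place of chloro it gives an at least 43-fold higher number from compound 1 to compound 3 (1.63 log units; beyond the scatter). The compounds shown leave open whether the carbonyl or the piperidine ring accounts for this large step. They also leave open how a primary amide, a carboxylic acid or an amine would read on this aromatic carbon.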